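This account rests on a few compounds, and the source may have more. Where it says the series, first, only, none or still open, it means among the compounds named here.

In a functional assay on MDA-MB-231 cells (Homo sapiens) for antiproliferative activity, read by MTT assay, with a stated time of 24 h (on this read-out higher numbers stand for weaker inhibition and lower numbers for stronger inhibition), compound 1 (`COC(=O)c1scc(-c2ccc(NC(=O)c3cccc(C(F)(F)F)c3)cc2)c1OC`) gives 24600 nM and compound 2 (`COC(=O)c1scc(-c2ccc(NC(=O)c3ccc(F)c(Cl)n3)cc2)c1OC`) gives 10300 nM which is the lower of the two numbers. Compound 2 therefore stands lowest of the pair so far. Compound 3 (`COC(=O)c1scc(-c2ccc(NC(=O)c3cccc(I)c3)cc2)c1OC`) has not yet been measured. Its difference from compound 2 is 3-iodophenyl in place of 6-chloro-5-fluoropyridin-2-yl on a carbonyl carbon and amounts to 3-iodophenyl in place of 6-chloro-5-fluoropyridin-2-yl on a carbonyl carbon.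

For the measured compounds named here, only one measured step bears on this change. It is a 2.4-fold lower number from compound 1 to compound 2 (0.38 log units; beyond the scatter) and it is modest, with 6-chloro-5-fluoropyridin-2-yl entering in place of 3-(trifluoromethyl)phenyl on the same carbonyl carbon. The new change removes that same group, and the 3-iodophenyl that enters is named like the group in compound 1 at 24600 nM so part of that modest step is expected to be reversed. With a single step as evidence, this expectation is loose. The expected size is a 2.0-fold higher number from compound 2 to compound 3 (0.31 log units; beyond the scatter) and it points toward a higher number. For compound 3 the estimated value is 21000 nM with an expected range from 9000 nM to 45000 nM in this estimate.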

Compound 3, half-maximal inhibitory concentration: 8240 nM
Compound 3: the middle estimate sits 2.5-fold (0.41 log units) above what was measured; the measured number lies below the stated range.
By their numbers in this assay, from the lowest: compounds 3 and 2 (each within the scatter of the next); then compound 1.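

In this assay the exchange on the carbonyl carbon gives a 1.3-fold lower number from compound 2 to compound 3 (0.10 log units; within the scatter), so the 3-iodophenyl and the 6-chloro-5-fluoropyridin-2-yl cannot be told apart here, even though one is a ring of carbon only and the other a ring with a hetero atom. The other new step shows that the single substituent on the carbon-only ring counts, since iodo in place of trifluoromethyl on an aromatic carbon gives a 3.0-fold lower number from compound 1 to compound 3 (0.48 log units; beyond the scatter), and this means that a ring hetero atom is not needed to move beyond the scatter from compound 1, which now has the highest number of the three with both of its steps beyond the scatter. Nothing available here accounts for these differences.

On these data alone, what a bromo, a nitrile or an amine on that same aromatic carbon would give stays open, and so does whether a single atom such as iodo and a larger group behave alike there. As far as these compounds go, it is also open whether a carboxylic acid in place of the methyl ester of the shared core would leave these steps as they stand, or whether a saturated ring on the carbonyl carbon would keep compound 3 and compound 2 within the scatter of it.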